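This account rests on a few compounds, and the source may have more. Where it says the series, first, only, none or still open, it means among the compounds named here.

Compound 1 `CCN(C)c1nc(Cc2c(F)cccc2F)cc(=O)[nH]1`: > 89000 nM
Compound 2 `CN1CCN(c2nc(Cc3c(F)cccc3F)cc(=O)[nH]2)CC1`: > 78000 nM
Compound 3 `CCN(C)c1nc(Cc2c(F)cccc2F)c(C)c(=O)[nH]1`: > 85000 nM

In an ADME assay on MT4 cells (Homo sapiens) for cytotoxicity, read by MTT assay, with a stated time of 4 days (a lower number here means that less compound is tolerated, a higher number that more compound is tolerated), all three entries are limits, not numbers. Compound 3 has only a limit, > 85000 nM, and the other two compounds offer nothing firmer to rank it against. The next compound is compound 4 `Cc1c(Cc2c(F)cccc2F)nc(N(C)C2CCCCC2)[nH]c1=O`, with cyclohexyl in place of ethyl on a nitrogen on an aromatic ring. Among the measured compounds shown here, two measured steps bear on this. One, a step that the two limits leave unreadable from compound 1 to compound 2, also replaced the amino group. The other, a step that the two limits leave unreadable from compound 1 to compound 3, added the methyl that compound 4 keeps. Neither has a readable size, so neither gives a direction. The expected step is an at least 1.3-fold lower number from compound 3 to compound 4 (0.11 log units; that floor lies within the scatter), no larger than the scatter. For compound 4 the estimated value is 65000 nM, with an expected range from 20000 nM to 95000 nM.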

Compound 4, half-maximal cytotoxic concentration: > 72000 nM
Compound 4 ended at the assay's limit (the forecaster's own chance of this, stated with the estimate: 65%); middle value at least 1.1-fold (0.04 log units) from the limit.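

Among the compounds shown here, compound 4 gives > 72000 nM, which is a limit and not a number; compound 3 also has only a limit, so no step between compound 3 and compound 4 can be read. The compounds shown leave open what concentration of any of them actually harms these cells.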